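This account rests on a few compounds, and the source may have more. Where it says the series, first, only, none or still open, it means among the compounds named here.

Compound 1 `O=C(/C=C\Nc1ccc(F)cc1)c1cn(-c2ccccc2)nc1-c1ccccc1`: 6870 nM
Compound 2 `O=C(/C=C\Nc1ccc(Cl)cc1)c1cn(-c2ccccc2)nc1-c1ccccc1`: 3610 nM
Compound 3 `O=C(/C=C\Nc1ccc(O)cc1)c1cn(-c2ccccc2)nc1-c1ccccc1`: 5000 nM

In a functional assay on HT-29 cells (Homo sapiens) for antiproliferative activity, read by MTT assay, with a stated time of 48 h (a lower number here means a stronger inhibitor, a higher number a weaker inhibitor), compound 2 has the lowest of the three numbers, yet the step of a 1.9-fold lower number from compound 1 to compound 2 (0.28 log units; within the scatter) and the step of a 1.4-fold higher number from compound 2 to compound 3 (0.14 log units; within the scatter) both fall within the scatter, so the three compounds cannot be told apart. Compound 4 `COc1ccc(-c2nn(-c3ccccc3)cc2C(=O)/C=C\Nc2ccc(Cl)cc2)cc1` differs from compound 2 by methoxy in place of hydrogen on an aromatic carbon. Within the data shown here, none of the measured steps touches this part of the molecule; each of them changed the group on the anilino ring instead, and none of them moved the number beyond the scatter. The expectation is therefore a step of no real size, a 1.0-fold lower number from compound 2 to compound 4 (0.01 log units; within the scatter). Compound 4 is estimated at 3500 nM, with a range from 1500 nM to 8500 nM.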

Compound 4, half-maximal inhibitory concentration: 4760 nM
Compound 4: the middle estimate sits 1.4-fold (0.13 log units) below what was measured; measured number inside the range.
By their numbers in this assay, from the lowest: compounds 2, 4, 3 and 1 (each within the scatter of the next).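

Turning phenyl into 4-methoxyphenyl is the first change shown away from the anilino ring, and in this assay the step stays small (a 1.3-fold higher number from compound 2 to compound 4 (0.12 log units; within the scatter)). This position therefore takes a methoxy group with no change that can be told from the scatter, at least with chloro on the anilino ring. No measurement shown bears on the reason for this.

As far as these compounds go, whether an amine, a carboxylic acid or a longer chain such as butoxy at this place would move the number beyond the scatter remains open. So does whether methoxy here behaves the same with fluoro or hydroxy on the anilino ring.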